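A few compounds are considered here, and "the series" means these few. Any claim that something is new, unique, unknown or untested is made for them only; others in the source may bear on it.

Compound 1 `CC(=O)N1C(NCc2ccc(C(=O)Nc3ccccc3N)cc2)=NC(=O)C1Cc1ccccc1` was examined in an assay on isolated protein for inhibition of protein deacetylase HDAC6 (Homo sapiens), read by fluorescence, with stated times of 3 h and 60 min (on this read-out higher numbers stand for weaker inhibition and lower numbers for stronger inhibition), where compound 1 returned only the assay limit, > 20000 nM. Compound 2 `Nc1cc(C(=O)O)ccc1NC(=O)c1ccc(CNc2nccc(-c3cccnc3)n2)cc1` likewise gave in this assay only the limit > 20000 nM. Compound 3 `CC(=O)N1C(NCc2ccc(C(=O)Nc3ccccc3N)cc2)=NC(=O)C1Cc1c[nH]c2ccccc12` also gave only the limit > 20000 nM. The step that the two limits leave unreadable from compound 1 to compound 3 therefore cannot be read, because of the limit of > 20000 nM in this assay, at which 3 of the 3 values shown sit. Compound 4 `Nc1ccccc1NC(=O)c1ccc(CNC2=NC(=O)C(Cc3ccccc3)N2)cc1` differs from compound 1 in that (hydrogen in place of acetyl on an amine nitrogen in a ring). Among the compounds with values here, no measured step touches this acetyl, so the three limits give only a floor and no direction. Compound 4 is therefore expected to stay near that limit, with an estimated 20000 nM (range 5000 nM to 100000 nM). The step of a number no higher from compound 1 to compound 4 (the limit leaves the size open) is estimated to lie within the scatter.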

Compound 4, half-maximal inhibitory concentration: > 20000 nM
Compound 4: a limit, no number; the forecaster's own chance of this, stated with the estimate: 70%; the middle value lies on the limit itself.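

Compound 4, like compound 1, gives only a limit and not a number in this assay, so the step between them cannot be read: the limit of > 20000 nM in this assay, at which 4 of the 4 values shown sit.

The compounds shown leave open which change, if any, would bring a measurable value in this assay.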